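This account rests on a few compounds, and the source may have more. Where it says the series, first, only, none or still open, it means among the compounds named here.

Working notes on the series. Compound 1 `N#Cc1cnc(NCc2cnccc2C(F)(F)F)cc1N[C@H]1C[C@@H](O)C1` is the parent; in an assay on isolated protein for inhibition of protein kinase C theta type (Homo sapiens), read by TR-FRET, with a stated time of 2 h (a higher number here means a weaker inhibitor, a lower number a stronger inhibitor), compound 1 gives 500 nM. Among the compounds with values here, compound 2 `CC1(C)C[C@@H](Nc2cc(NCc3cnccc3C(F)(F)F)ncc2C#N)CC[C@@H]1O` carries a larger ring at the same aromatic nitrogen, and in this assay compound 2 gives 120 nM; the step of a 4.2-fold lower number from compound 1 to compound 2 (0.62 log units; beyond the scatter) is the only measured step so far. Compound 2 therefore stands with the lowest number of the two values known in this assay, beyond the scatter from compound 1.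

Compound 3 `CC1(C)[C@@H](C(N)=O)C[C@H]1Nc1cc(NCc2cnccc2C(F)(F)F)ncc1C#N` is not yet measured. Its change is 3-carbamoyl-2,2-dimethylcyclobutyl in place of 4-hydroxy-3,3-dimethylcyclohexyl on a nitrogen on an aromatic ring. Within the data shown here, the one measured step that bears on it, a 4.2-fold lower number from compound 1 to compound 2 (0.62 log units; beyond the scatter), concerns the same attachment point and shows that enlarging the ring from a four-membered to a six-membered one lowered the number modestly; compound 3 returns to a four-membered ring while keeping the two methyl groups and swapping hydroxyl for carbamoyl. Among the measured compounds shown here, no measured pair separates those two effects. A small rise toward the number of compound 1 is therefore expected, possibly within the scatter, as a 2.1-fold higher number from compound 2 to compound 3 (0.32 log units; beyond the scatter). Compound 3 is estimated at 250 nM, with a range of 90 nM to 700 nM.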

Compound 3, half-maximal inhibitory concentration: 1.4 nM
For compound 3 the middle estimate is 180-fold (2.25 log units) above the measured one; the whole stated range lies above it.
By their numbers in this assay, from the lowest: compound 3; then compound 2; then compound 1.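

At the nitrogen on the aromatic ring, ring size alone does not order these compounds: in this assay the 3-carbamoyl-2,2-dimethylcyclobutyl group brings a large gain over the six-membered ring (an 86-fold lower number from compound 2 to compound 3 (1.93 log units; beyond the scatter)) and a still larger one over the 3-hydroxycyclobutyl group (a 360-fold lower number from compound 1 to compound 3 (2.55 log units; beyond the scatter)). Compound 1 and compound 3 both carry a four-membered ring, yet they stand at opposite ends of the three values, so this position tolerates far more than the modest earlier step suggested. No measurement given here accounts for the gain.

The compounds shown leave open how much of the gain belongs to the carbamoyl group and how much to the two methyl groups; no pair changes one alone. From the compounds shown here alone, whether a carboxylic acid or a methyl ester in place of the carbamoyl group, or another stereoisomer of the cyclobutyl ring, would hold this level also remains open.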